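This account rests on a few compounds, and the source may have more. Where it says the series, first, only, none or still open, it means among the compounds named here.

Measured in the series:
compound 1, `Cc1nc(S)n(Nc2cccc(Cl)c2)c1-c1ccc(Cl)cc1`, 40800 nM in a functional assay on MT4 cells (Homo sapiens) for cytotoxicity; a higher number here means that more compound is tolerated, a lower number that less compound is tolerated
compound 2, `Cc1nc(S)n(Nc2cccc(Cl)c2)c1-c1cccc(Cl)c1`, 31000 nM in this assay
compound 3, `Cc1nc(S)n(Nc2cccc(Cl)c2)c1-c1ccccc1`, 66700 nM in this assay

Compound 3 gives the highest number of the three in this assay, but its margin over compound 1 is small, a 1.6-fold higher number from compound 1 to compound 3 (0.21 log units; within the scatter); only the gap to compound 2 is beyond the scatter, a 2.2-fold higher number from compound 2 to compound 3 (0.33 log units; beyond the scatter).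

Compound 4, `Cc1nc(S)n(Nc2cccc(Cl)c2)c1-c1cccc(Br)c1`, differs from compound 3 by bromo in place of hydrogen on an aromatic carbon. Going by the values given here, no bromo compound has been measured, so the closest guide is the step from compound 2 to compound 3, which replaces a chloro at the same place by hydrogen and raises the number modestly, a 2.2-fold higher number from compound 2 to compound 3 (0.33 log units; beyond the scatter). Read in reverse, putting a halogen back onto that aromatic carbon should lower the number by a modest amount. The step from compound 1 to compound 3, a 1.6-fold higher number from compound 1 to compound 3 (0.21 log units; within the scatter), points the same way but lies within the scatter.

Compound 4 is therefore expected to sit somewhat below compound 3 in this assay, with the step estimated as a 2.4-fold lower number from compound 3 to compound 4 (0.38 log units; beyond the scatter). The estimate for compound 4 is 28000 nM, with a range of 14000 nM to 56000 nM.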

Compound 4, half-maximal cytotoxic concentration: 44000 nM
Compound 4: middle estimate off by 1.6-fold (0.20 log units), on the low side; the measured number falls inside the stated range.
By their numbers in this assay, from the lowest: compounds 2, 1, 4 and 3 (each within the scatter of the next, the first and the last beyond it).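

In this assay the new value puts bromo on this aromatic carbon within the scatter of hydrogen (a 1.5-fold lower number from compound 3 to compound 4 (0.18 log units; within the scatter)) and also of chloro at the same place (a 1.4-fold higher number from compound 2 to compound 4 (0.15 log units; within the scatter)), so compound 4 cannot be separated from either of these compounds. The only gap beyond the scatter at this carbon remains the one between chloro and hydrogen (a 2.2-fold higher number from compound 2 to compound 3 (0.33 log units; beyond the scatter)); it does not carry over to bromo, so a general halogen effect at this place is not supported, and compound 4 also lies within the scatter of the 4-chlorophenyl compound (a 1.1-fold higher number from compound 1 to compound 4 (0.03 log units; within the scatter)). Nothing on hand offers an explanation for these numbers.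

From the compounds shown here alone, it remains open whether a group of another kind on this carbon, such as a methoxy, an amine or a carboxylic acid, would give a number clearly apart from that of the unsubstituted phenyl. Also open, going by these compounds, is whether the single gap beyond the scatter reflects a real difference between chloro and hydrogen, since it rests on one pair of compounds.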